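Sulfonyl aryl substituent series: cytotoxicity on L02 cells

This account rests on a few compounds, and the source may have more. Where it says the series, first, only, none or still open, it means among the compounds named here.

Measured so far:
- compound 1 `Cc1ccc(S(=O)(=O)N2C/C(=C\c3ccc(F)cc3)C(=O)/C(=C/c3ccc(F)cc3)C2)cc1`: 14000 nM
- compound 2 `O=C1/C(=C/c2ccc(F)cc2)CN(S(=O)(=O)c2ccc(F)cc2)C/C1=C\c1ccc(F)cc1`: 14800 nM

Within the data shown here, in an ADME assay on L02 cells (Homo sapiens) for cytotoxicity, read by MTT assay, with a stated time of 24 h (on this read-out lower numbers stand for stronger inhibition and higher numbers for weaker inhibition), compound 2 gives 14800 nM, the highest of the two numbers in hand; its only neighbour is compound 1, and a 1.1-fold higher number from compound 1 to compound 2 (0.02 log units; within the scatter) leaves the two within the scatter. Compound 3 `N#Cc1ccc(S(=O)(=O)N2C/C(=C\c3ccc(F)cc3)C(=O)/C(=C/c3ccc(F)cc3)C2)cc1` is not yet measured. Among the measured compounds shown here, it differs from compound 2 by cyano in place of fluoro on an aromatic carbon, the same place on the sulfonyl aryl ring that the one measured step alters. That step, a 1.1-fold higher number from compound 1 to compound 2 (0.02 log units; within the scatter), exchanged one small group for another at this place and moved this assay by nothing beyond the scatter. For the measured compounds named here, only one such step is known, so it is a thin basis, but it points to no shift beyond the scatter when the fluoro gives way to cyano. Compound 3 is therefore expected to give 15000 nM (range 7000 nM to 32000 nM), a step of a 1.0-fold higher number from compound 2 to compound 3 (0.01 log units; within the scatter).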

Compound 3, half-maximal inhibitory concentration: 14700 nM
Compound 3: the middle estimate sits 1.0-fold (0.01 log units) above what was measured, and the stated range covers the measured number.
By their numbers in this assay, from the lowest: compounds 1, 3 and 2 (each within the scatter of the next).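

In this assay, cyano in place of fluoro on the aromatic carbon para to a large group leaves the number within the scatter (a 1.0-fold lower number from compound 2 to compound 3 (0.00 log units; within the scatter)), and the same holds for cyano in place of methyl (a 1.1-fold higher number from compound 1 to compound 3 (0.02 log units; within the scatter)). The position has now taken methyl, fluoro and cyano, and the cyano group's triple bond and hydrogen-bond acceptor, which fluoro lacks, bring no step beyond the scatter in this assay within this set of compounds. Nothing measured here gives a reason for the numbers lying so close together.

Still open, on these data alone, is whether an amine, a carboxylic acid or a longer chain on this aromatic carbon would stay within the scatter of these three compounds. Also open, as far as these compounds go, is how this assay responds to changes elsewhere on the shared core, such as replacing its fluorophenyl groups.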